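Trifluoromethyl for methyl on a shared amide core

The compounds below may be only part of what the source reports. "The series", "measured", "known", "first", "only" and "open" are said of these compounds alone.

The three compounds measured share a core that is seen in compound 1, `CCOc1ccc(C(=O)Nc2cccc(NC(=O)COc3ccc4c(=O)ccoc4c3)c2)cc1`, which in an assay on isolated protein for inhibition of Rho-associated protein kinase 2 (Homo sapiens), read by scintillation counting, radiometric assay and 33P incorporation, with a stated time of 40 min, in the presence of a further agent that is not named here (a lower number here means a stronger inhibitor, a higher number a weaker inhibitor), gives 9 nM. Compound 2, `CN(C)c1ccc(S(=O)(=O)Nc2cccc(NC(=O)COc3ccc4c(=O)ccoc4c3)c2)cc1`, gives 263 nM in this assay. Compound 3, `Cc1cc(NC(=O)COc2ccc3c(=O)ccoc3c2)cc(NC(=O)c2ccc(N(C)C)cc2)c1`, reaches only a limit in this assay, > 10000 nM, so no number is known for it. Compound 3 stands at the weak end of what has been measured, at the limit of > 10000 nM in this assay, at which 1 of the 3 values shown sits.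

Compound 4, `CN(C)c1ccc(C(=O)Nc2cc(NC(=O)COc3ccc4c(=O)ccoc4c3)cc(C(F)(F)F)c2)cc1`, has not been measured. It differs from compound 3 in one place: trifluoromethyl in place of methyl on an aromatic carbon, the group sitting, in the words of the comparison, on an aromatic carbon of a six-membered aromatic ring of carbon only, meta to two large groups. Among the measured compounds shown here, no measured pair isolates this change, and compound 3 itself offers only a limit to build on. The step from compound 3 to compound 4 in this assay is expected to be small or none beyond the scatter, a step that the limit leaves unreadable from compound 3 to compound 4, with compound 4 most likely again reported as a limit. For compound 4 the estimate in this assay is 15000 nM, within a range from 3000 nM to 60000 nM.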

Compound 4, half-maximal inhibitory concentration: > 10000 nM
Compound 4 gave a limit, no number; the forecaster's own chance of this, stated with the estimate: 65%; the middle value lies beyond the limit too.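

In this assay compound 3 gives > 10000 nM, which is a limit and not a number. Compound 4 gives > 10000 nM, again a limit, so no step can be read between compound 3 and compound 4: the limit of > 10000 nM in this assay, at which 2 of the 4 values shown sit. The compounds shown leave open what trifluoromethyl in place of methyl on an aromatic carbon does where both partners give a number.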